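Dropping the fluorine from a thiazolylidene hydrazide

The source may hold more compounds than are shown below. What is called first, only, known or untested is meant among the compounds shown, and "the series" means these compounds.

Compounds measured so far:
compound 1 `Cc1nnc(SCC(=O)N/N=c2/scc(-c3ccc(F)cc3)n2-c2ccccc2)s1` — 50.1%
compound 2 `Cc1nnc(SCC(=O)N/N=c2/scc(-c3ccc(Cl)cc3)n2-c2ccccc2)s1` — 53.3%
compound 3 `O=C(CSc1nnnn1-c1ccccc1)N/N=c1/scc(-c2ccc(F)cc2)n1-c1ccccc1` — 49.3%

In a functional assay on C6 cells (Rattus norvegicus) for cytotoxicity, read by MTT assay, with a stated time of 24 h, tested at 25 ug/mL (a lower number here means a stronger effect, a higher number a weaker effect of the compound at the concentration tested), compound 1 gives 50.1%, compound 2 gives 53.3% and compound 3 gives 49.3%. Compound 3 has the lowest of the three numbers, but its nearest neighbour is compound 1 at a number 0.8 percentage points lower from compound 1 to compound 3 (within the scatter), and compound 2 lies only a number 3.2 percentage points higher from compound 1 to compound 2 (within the scatter) away from compound 1, so the three values sit together within the scatter of this assay.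

Compound 4 `O=C(CSc1nnnn1-c1ccccc1)N/N=c1/scc(-c2ccccc2)n1-c1ccccc1` differs from compound 3 in one place: hydrogen in place of fluoro on an aromatic carbon. Among the compounds with values here, no measured step removes a halogen outright; the closest is the halogen swap a number 3.2 percentage points higher from compound 1 to compound 2 (within the scatter), and the change of the sulfur-bound heterocycle a number 0.8 percentage points lower from compound 1 to compound 3 (within the scatter) was likewise small. Neither step moved the read-out beyond the scatter, so compound 4 is expected to stay close to compound 3, with an estimated step of a number 0.7 percentage points higher from compound 3 to compound 4 (within the scatter). Compound 4 is therefore estimated at 50%, within a range of 38% to 62%.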

Compound 4, a percentage reported as activity, at one concentration (the size of the read-out at that concentration, not a potency): 42.5%
Compound 4: the middle estimate sits 7.5 percentage points above what was measured; the measured number falls inside the stated range.
By their numbers in this assay, from the lowest: compounds 4, 3, 1 and 2 (each within the scatter of the next, the first and the last beyond it).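

Taking the fluoro off the 4-fluorophenyl ring is the first step shown that removes the halogen outright rather than exchanging it, and in this assay it reads a number 6.8 percentage points lower from compound 3 to compound 4 (within the scatter) at a single tested concentration. Together with the exchange of fluoro for chloro, a number 3.2 percentage points higher from compound 1 to compound 2 (within the scatter) in the series carrying the 5-methyl-1,3,4-thiadiazol-2-yl group on sulfur, this means that neither change at this position, para to a large group, moves the read-out beyond the scatter. No accompanying data bear on why this step has the size it has.

As far as these compounds go, it remains open whether the loss of fluoro would read the same with the 5-methyl-1,3,4-thiadiazol-2-yl group on sulfur. From the compounds shown here alone, it is also open whether a group of another kind at this position, such as an amine or a methoxy group, would take the read-out beyond the scatter.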